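Aryl swap at the chain carbon of the guanidine series

This account rests on a few compounds, and the source may have more. Where it says the series, first, only, none or still open, it means among the compounds named here.

In a functional assay on cardiac atrium for agonist activity at histamine H2 receptor (Cavia porcellus) (a lower number here means a smaller maximal response, a higher number a larger maximal response), compound 1 `N=C(NCCCc1c[nH]cn1)NCCC(c1ccccc1)c1ccccn1` gives 1, compound 2 `N=C(NCCCc1c[nH]cn1)NCCC(c1ccc(Cl)cc1)c1ccccn1` gives 1 and compound 3 `N=C(NCCCc1c[nH]cn1)NCCC(c1cc(F)cc(F)c1)c1ccccn1` gives 1. Compound 3 thus stands level with compounds 1 and 2 at the digits shown. Among the measured compounds shown here, the steps so far are flat: no change at the digits printed from compound 1 to compound 2 (within the scatter), no change at the digits printed from compound 1 to compound 3 (within the scatter) and no change at the digits printed from compound 2 to compound 3 (within the scatter). Compound 4 `N=C(NCCCc1c[nH]cn1)NCCC(c1ccccn1)c1ccccn1` differs from compound 3 by pyridin-2-yl in place of 3,5-difluorophenyl on a saturated chain carbon bound to an aromatic carbon and a saturated chain carbon. The flat steps from compound 1 to compound 3 and from compound 2 to compound 3 bear most directly on this change, both altering the same chain-carbon aryl group without effect, so no step beyond the scatter is expected in this assay, that is no change at the digits printed from compound 3 to compound 4 (within the scatter). The expected value for compound 4 is 1, between 0.85 and 1.05.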

Compound 4, intrinsic activity: the largest response reached, as a fraction of the reference agonist's: 1
Estimate against measurement, compound 4: no gap at the digits printed, within the range that was stated.
By their numbers in this assay, from the lowest: compounds 1, 2, 3 and 4 (each within the scatter of the next).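

In this assay the read-out stays flat when pyridin-2-yl enters on the saturated chain carbon, with no change at the digits printed from compound 3 to compound 4 (within the scatter) and no change at the digits printed from compound 2 to compound 4 (within the scatter) and no change at the digits printed from compound 1 to compound 4 (within the scatter) as the steps. The aromatic ring at this place can therefore carry a hetero atom and a hydrogen-bond acceptor, whereas the earlier groups here were carbon-only rings, and the maximal response holds. No measurement explains this flatness.

Still open, on these data alone, is whether a non-aromatic group at this place, such as a primary amine or a carboxylic acid, would hold the response in this assay as well.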